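Swapping the urea linkage for a carbamate on a shared core

The compounds below may be only part of what the source reports. "The series", "measured", "known", "first", "only" and "open" are said of these compounds alone.

- compound 1 `Cc1noc(C)c1NC(=O)N1CCC(c2nc(-c3ccc4ccccc4n3)no2)CC1` in a functional assay on Shh Light II cells (Mus musculus) for inhibition, read by a luciferase reporter (a higher number here means a weaker inhibitor, a lower number a stronger inhibitor), gives 3000 nM
- compound 2 `O=C(NC1CCNCC1)N1CCC(c2nc(-c3ccc4ccccc4n3)no2)CC1` gives 2500 nM
- compound 3 `O=C(Nc1ncccc1Cl)N1CCC(c2nc(-c3ccc4ccccc4n3)no2)CC1` gives 2800 nM

Compound 1 has the highest of the three numbers, yet the others sit very close to it: a 1.2-fold lower number from compound 1 to compound 2 (0.08 log units; within the scatter) and a 1.1-fold lower number from compound 1 to compound 3 (0.03 log units; within the scatter) are both within the scatter, and so is a 1.1-fold higher number from compound 2 to compound 3 (0.05 log units; within the scatter). Compound 4 `COc1ccccc1OC(=O)N1CCC(c2nc(-c3ccc4ccccc4n3)no2)CC1` is not yet measured. It differs from compound 1 in one place: 2-methoxyphenoxy in place of (3,5-dimethyl-1,2-oxazol-4-yl)amino on a carbonyl carbon. The two measured steps from compound 1 bear on this, since each also exchanges the group on that carbonyl carbon and neither moved the number beyond the scatter. The new change goes further, exchanging the whole amino linkage rather than only the ring on it, so some uncertainty remains. Still, the expectation is for no step beyond the scatter, no change at the digits printed from compound 1 to compound 4 (within the scatter). Compound 4 is expected to give 3000 nM, in a range from 1000 nM to 9000 nM.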

Compound 4, half-maximal inhibitory concentration: 250 nM
The estimate for compound 4 lay 12-fold (1.08 log units) above the measured number; the whole stated range lies above it.
By their numbers in this assay, from the lowest: compound 4; then compounds 2, 3 and 1 (each within the scatter of the next).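

Three different amino groups on this carbonyl carbon left the number unchanged within the scatter in this assay, so this position looked insensitive, but 2-methoxyphenoxy gives a 12-fold lower number from compound 1 to compound 4 (1.08 log units; beyond the scatter) and an 11-fold lower number from compound 3 to compound 4 (1.05 log units; beyond the scatter) and a 10-fold lower number from compound 2 to compound 4 (1.00 log units; beyond the scatter) in a single change. Compound 4 is thus the strongest inhibitor of the four. No evidence here explains the gain. From the compounds shown here alone, this change replaces the linking nitrogen and the ring together, so the contribution of each remains open. A (2-methoxyphenyl)amino group or a plain phenoxy group would separate them.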